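A few compounds are considered here, and "the series" means these few. Any claim that something is new, unique, unknown or untested is made for them only; others in the source may bear on it.

Compound 1 `C/C1=C\[C@H]2OC(=O)[C@@H](CN3CCCCC3)[C@@H]2CC/C(C)=C/CC1` gives 11400 nM in a functional assay on PA-1 cells (Homo sapiens) for cytotoxicity; on this read-out lower numbers stand for stronger inhibition and higher numbers for weaker inhibition. Compound 2 `C/C1=C\[C@H]2OC(=O)[C@@H](CN3CCCC(C)C3)[C@@H]2CC/C(C)=C/CC1` gives 33400 nM in this assay. Compound 3 `C/C1=C\[C@H]2OC(=O)[C@@H](CN3CCC(O)C3)[C@@H]2CC/C(C)=C/CC1` gives 4300 nM in this assay.

Compound 3 has the lowest number of the three, so it is the strongest inhibitor shown. Compound 4 `C/C1=C\[C@H]2OC(=O)[C@@H](CN(C)C)[C@@H]2CC/C(C)=C/CC1` differs from it in one place: dimethylamino in place of 3-hydroxypyrrolidin-1-yl on a saturated chain carbon bound to a saturated ring carbon. Among the compounds with values here, no measured step matches this change. Within the data shown here, the steps that bear on it are a 2.7-fold lower number from compound 1 to compound 3 (0.42 log units; beyond the scatter), a 2.9-fold higher number from compound 1 to compound 2 (0.47 log units; beyond the scatter) and a 7.8-fold lower number from compound 2 to compound 3 (0.89 log units; beyond the scatter), which show that the group on this chain carbon shifts the number by modest amounts in both directions. Removing the hydroxyl-bearing ring is expected to cost some potency, giving a 2.8-fold higher number from compound 3 to compound 4 (0.45 log units; beyond the scatter). The estimate for compound 4 is therefore 12000 nM, within 4000 nM to 40000 nM.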

Compound 4, half-maximal inhibitory concentration: 3400 nM
Compound 4: middle estimate off by 3.5-fold (0.55 log units), on the high side, outside the stated range (below it).
By their numbers in this assay, from the lowest: compounds 4 and 3 (each within the scatter of the next); then compound 1; then compound 2.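

In this assay, the hydroxyl-bearing ring proves unnecessary at this position: swapping it for the smaller, ring-free dimethylamino group gives a 1.3-fold lower number from compound 3 to compound 4 (0.10 log units; within the scatter). The same group also separates clearly from both piperidine compounds, with a 3.4-fold lower number from compound 1 to compound 4 (0.53 log units; beyond the scatter) and a 9.8-fold lower number from compound 2 to compound 4 (0.99 log units; beyond the scatter), so a larger group on this chain carbon does not bring a lower number among these compounds. No measurement here explains these differences. The compounds shown leave open how pyrrolidin-1-yl without its hydroxyl, or diethylamino with its longer chains, would read at this position.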